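Pyrazoline amides: pyridinyl carbonyl swap on a benzyloxy core

The compounds below may be only part of what the source reports. "The series", "measured", "known", "first", "only" and "open" are said of these compounds alone.

Measured compounds:
compound 1 `COc1ccc(C2=NN(C(=O)c3cncc(Br)c3)C(c3ccc(Cl)cc3)C2)cc1` — 1290 nM
compound 2 `COc1ccc(C2=NN(C(=O)c3ccc(Cl)nc3)C(c3ccc(Cl)cc3)C2)cc1` — 1450 nM
compound 3 `O=C(c1cncc(Br)c1)N1N=C(c2ccc(Cl)cc2)CC1c1ccc(OCc2ccccc2)cc1` — 8130 nM

In a functional assay on WM 266-4 cells (Homo sapiens) for antiproliferative activity, read by MTT assay, with a stated time of 24 h (on this read-out higher numbers stand for weaker inhibition of growth and lower numbers for stronger inhibition of growth), compound 1 gives 1290 nM and compound 2 gives 1450 nM. The change between them is 6-chloropyridin-3-yl in place of 5-bromopyridin-3-yl on a carbonyl carbon and the step is a 1.1-fold higher number from compound 1 to compound 2 (0.05 log units; within the scatter). Compound 3 carries a different core; how it differs from compound 1 is not broken down here. In this assay compound 3 gives 8130 nM, the highest number among the three measured compounds, beyond the scatter from both compound 1 and compound 2.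

Compound 4 `O=C(c1ccc(Cl)nc1)N1N=C(c2ccc(Cl)cc2)CC1c1ccc(OCc2ccccc2)cc1` is not yet measured. It differs from compound 3 by 6-chloropyridin-3-yl in place of 5-bromopyridin-3-yl on a carbonyl carbon, the same change as from compound 1 to compound 2, at the same kind of place. On the core of compound 1 that change left the number essentially unchanged, so for compound 4 a step of about a 1.1-fold higher number from compound 3 to compound 4 (0.04 log units; within the scatter) is expected in this assay, resting on compound 3 at 8130 nM and on the earlier step of a 1.1-fold higher number from compound 1 to compound 2 (0.05 log units; within the scatter). The estimate for compound 4 is 9000 nM, expected to lie between 4000 nM and 20000 nM.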

Compound 4, concentration for 50% growth inhibition: 13200 nM
For compound 4 the middle estimate is 1.5-fold (0.17 log units) below the measured one; the range from low to high includes it.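

In this assay, 6-chloropyridin-3-yl in place of 5-bromopyridin-3-yl on a carbonyl carbon gives a 1.6-fold higher number from compound 3 to compound 4 (0.21 log units; within the scatter). Set beside the earlier step, the change reads the same on both cores, with no difference that can be told from the scatter: the same change on two cores in this assay, a 1.1-fold higher number (0.05 log units; within the scatter) from compound 1 to compound 2 and a 1.6-fold higher number (0.21 log units; within the scatter) from compound 3 to compound 4, 1.4-fold (0.16 log units) apart, within the scatter of two such steps. Among these compounds, this supports carrying the change between these two cores without a measurable shift in the number, but it rests on only two pairs and does not show that the same would hold on any other core, nor does it show a real effect of the change on either core.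

Still open, going by these compounds, is whether a group of another kind on the carbonyl carbon, such as a pyridinyl carrying an amine or a phenyl carrying a carboxylic acid, would give a step beyond the scatter on either core. Also open, on these data alone, is whether the change reads the same on a core with a hydroxyl or a longer alkoxy chain where compound 4 has its benzyloxy group.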